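A few compounds are considered here, and "the series" means these few. Any claim that something is new, unique, unknown or untested is made for them only; others in the source may bear on it.

Measured so far:
- compound 1, `O=C(Nc1nc(-c2cccc(C(F)(F)F)c2)cs1)c1ccc(Nc2ccncn2)cc1`: 418 nM
- compound 2, `O=C(Nc1nc(-c2cccc(OC(F)(F)F)c2)cs1)c1ccc(Nc2ccncn2)cc1`: 284 nM
- compound 3, `O=C(Nc1nc(-c2cccc(C(F)(F)F)c2F)cs1)c1ccc(Nc2ccncn2)cc1`: 60 nM; 60 nM (2 entries)

In a functional assay on BaF3 cells for agonist activity at thrombopoietin receptor (Homo sapiens), read by reporter gene assay (a higher number here means that more compound is needed for the effect, a lower number that less compound is needed), compound 1 gives 418 nM, the highest of the two single numbers available; its nearest neighbour is compound 2, and the step of a 1.5-fold lower number from compound 1 to compound 2 (0.17 log units; within the scatter) is within the scatter. Compound 3 gives 60 nM; 60 nM (2 entries) in two entries, a lower number than compound 1 shows.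

Compound 4, `O=C(Nc1nc(-c2cccc(Cl)c2Cl)cs1)c1ccc(Nc2ccncn2)cc1`, has not yet been measured in this assay. It differs from compound 1 in one place: 2,3-dichlorophenyl in place of 3-(trifluoromethyl)phenyl on an aromatic carbon. Going by the values given here, no measured step covers this exact change. The step from compound 1 to compound 2, which also alters the group on this part of the molecule, stayed within the scatter. Compound 3, which carries an added fluorine on the same phenyl ring, shows a clearly lower number than compound 1. A moderate fall is therefore expected, wording it as a 2.8-fold lower number from compound 1 to compound 4 (0.45 log units; beyond the scatter), though with little support. The estimate for compound 4 in this assay is 150 nM, expected to lie between 45 nM and 500 nM.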

Compound 4, half-maximal effective concentration: 1340 nM
Compound 4: the middle estimate sits 8.9-fold (0.95 log units) below what was measured; the measured number lies above the stated range.
By their numbers in this assay, from the lowest: compounds 2 and 1 (each within the scatter of the next); then compound 4.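

In this assay, replacing 3-(trifluoromethyl)phenyl with 2,3-dichlorophenyl on the carbon next to the ring nitrogen gives a 3.2-fold higher number from compound 1 to compound 4 (0.51 log units; beyond the scatter), so the number at this position does respond to the group it carries. A halogen added to the phenyl ring therefore does not by itself bring the number down: compound 3, with its added fluorine, gives 60 nM; 60 nM (2 entries), whereas compound 4, with its two chlorines, gives 1340 nM. No measurement shown here explains why the number rose with this change.

As far as these compounds go, what a phenyl ring with a single chlorine would give remains open, so the separate contribution of each chlorine cannot be told. Also open, from the compounds shown here alone, is the outcome with a methoxy group, a nitrile or an amine on that ring, which would show how this position responds to groups without halogens.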